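The source may report more compounds than this note shows. Statements on the series, on what has been measured and on what is new or still open speak of the compounds shown alone.

Working notes on the series. Compound 1 `O=c1c2cc(-c3ccc(Cl)cc3)cn2ncn1-c1ccc(N2CC(O)C2)nc1` gives 14 nM in an assay on isolated protein for displacement of a labelled ligand from melanin-concentrating hormone receptor 1 (Rattus norvegicus), read by scintillation counting (a lower number here means a stronger inhibitor, a higher number a weaker inhibitor), and stands at the lower of the two numbers recorded so far. Within the data shown here, compound 2 `O=c1c2cc(-c3ccc(Cl)cn3)cn2ncn1-c1ccc(N2CC[C@@H](O)C2)nc1` gives 54 nM in this assay, a gap from compound 1 that is beyond the scatter; the two differ in more than one place, so the pair gives no single counted step and only the two values themselves are noted.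

Compound 3 `O=c1c2cc(-c3ccc(Cl)cc3)cn2ncn1-c1ccc(N2CCC(O)CC2)nc1` is not yet measured. Relative to compound 1 the change is 4-hydroxypiperidin-1-yl in place of 3-hydroxyazetidin-1-yl on an aromatic carbon: a larger ring carrying the same hydroxyl and the same count of donors and acceptors. Among the measured compounds shown here, no measured pair isolates this change, so there is no step to lean on. The expected step from compound 1 to compound 3 is a 1.6-fold higher number from compound 1 to compound 3 (0.20 log units; within the scatter), a modest shift that may not exceed the scatter. Compound 3 is estimated at 22 nM, with a range from 7 nM to 65 nM.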

Compound 3, inhibition constant: 18 nM
Compound 3: the middle estimate sits 1.2-fold (0.09 log units) above what was measured, within the range that was stated.
By their numbers in this assay, from the lowest: compounds 1 and 3 (each within the scatter of the next); then compound 2.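

In this assay, among these compounds, 4-hydroxypiperidin-1-yl in place of 3-hydroxyazetidin-1-yl on this aromatic carbon gives a 1.3-fold higher number from compound 1 to compound 3 (0.11 log units; within the scatter), the first single-place reading. At this position, next to the ring nitrogen, the six-membered ring with its hydroxyl therefore cannot be told apart from the four-membered one, despite the larger group entering. No measurement bears on why the two rings read alike.

Every compound shown carries a hydroxyl on this saturated ring, so it remains open what a plain piperidin-1-yl, a morpholin-4-yl or an amine in place of the hydroxyl would give. Going by these compounds, compound 2 differs from compound 1 in more than one place, so it also remains open which of those places carries the gap in this assay.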